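The source may hold more compounds than are shown below. What is called first, only, known or untested is meant among the compounds shown, and "the series" means these compounds.

Compound 1 `O=C(CCCCC1CCSS1)Nc1ccc([N+](=O)[O-])c(C(F)(F)F)c1` is tested in a functional assay on Bel-7402 cells (Homo sapiens) for inhibition, read by MTT assay, with a stated time of 24 h, tested at 100 ug/mL (a higher number here means more inhibition of growth at the concentration tested, a lower number less inhibition of growth), and gives 23.9% there. Compound 3 `O=C(CCCCC(S)CCS)Nc1ccc([N+](=O)[O-])c(C(F)(F)F)c1` carries one change relative to compound 1, namely (a group of 5 heavy atoms (3 carbon, 2 sulfur; no ring) in place of a group of 5 heavy atoms (3 carbon, 2 sulfur; one five-membered non-aromatic ring with 2 hetero atoms), on a saturated chain carbon, four bonds along the chain from a carbonyl carbon), and in this assay compound 3 gives 91.7%, so that the step of a number 67.8 percentage points higher from compound 1 to compound 3 (beyond the scatter). Compound 2 `O=C(CCCCC1CCSS1)Nc1cccc2ccccc12` shares the amide and the chain with compound 1 but has a different core; the difference between the two cores is not broken down here. In this assay compound 2 gives 7.22%. Compound 4 `O=C(CCCCC(S)CCS)Nc1cccc2ccccc12` is not yet measured; relative to compound 2 it carries a group of 5 heavy atoms (3 carbon, 2 sulfur; no ring) in place of a group of 5 heavy atoms (3 carbon, 2 sulfur; one five-membered non-aromatic ring with 2 hetero atoms), on a saturated chain carbon, four bonds along the chain from a carbonyl carbon, the same change as that from compound 1 to compound 3. A step of similar size is expected, a number 62.8 percentage points higher from compound 2 to compound 4 (beyond the scatter), because in compound 1 and compound 3 this change gave a number 67.8 percentage points higher from compound 1 to compound 3 (beyond the scatter). For compound 4 in this assay the expected value is therefore 70%, within about 40% to 92%.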

Compound 4, percent growth inhibition at one concentration: "not active" (no number reported)
For compound 4 the study gives words and no number, so the estimate cannot be set against anything.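

Going by these compounds alone, compound 4 is reported only as "not active", with no number, so no step from compound 2 to compound 4 can be read. The compounds shown leave open whether 1,3-disulfanylpropyl in place of the ring acts alike on both cores. No evidence given here bears on this result.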